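Cytotoxicity notes on the amide-nitrogen substituent variants

The source may hold more compounds than are shown below. What is called first, only, known or untested is meant among the compounds shown, and "the series" means these compounds.

Compound 1 `COc1ccc([C@H]2CC(=O)N(c3ccc(C)c(N)c3)C2)cc1OC1CCCC1` is the reference in a functional assay on HEK293 cells (Homo sapiens) for cytotoxicity; on this read-out lower numbers stand for higher toxicity in this test and higher numbers for lower toxicity in this test. In this assay compound 1 returns only a limit, > 10000 nM. Compound 2 `COc1ccc([C@H]2CC(=O)N(c3cccc(C)c3)C2)cc1OC1CCCC1` likewise gives a limit in this assay, > 10000 nM. The step that the two limits leave unreadable from compound 1 to compound 2 is therefore unreadable; both values shown sit at the limit of > 10000 nM in this assay, at which 2 of the 2 values shown sit. Compound 3 `COc1ccc([C@H]2CC(=O)N(c3cccc(C(F)(F)F)c3)C2)cc1OC1CCCC1` is the next variant, differing from compound 1 by 3-(trifluoromethyl)phenyl in place of 3-amino-4-methylphenyl on an amide-type nitrogen in a ring. Among the measured compounds shown here, the one measured step bears on it only in that exchanging the group on an amide-type nitrogen in a ring left the readout at a limit in this assay, with no step beyond the scatter readable. The expected step is a step that the limit leaves unreadable from compound 1 to compound 3, a limit again being the likeliest result in this assay. For compound 3 the estimate in this assay is 15000 nM, with a range from 7000 nM to 50000 nM.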

Compound 3, half-maximal cytotoxic concentration: > 10000 nM
Compound 3 was reported as a limit; the forecaster's own chance of this, stated with the estimate: 80%; the middle value does not contradict the limit.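

In this assay, among the compounds shown here, compound 3 gives > 10000 nM, again a limit, so no step from compound 1 or compound 2 to compound 3 can be read. Whether the groups on the amide-type nitrogen differ at all in cytotoxicity among compound 1, compound 2 and compound 3 stays open: the limit of > 10000 nM in this assay, at which 3 of the 3 values shown sit.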